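From 4-bromophenyl to 2-bromophenyl on the sulfonyl sulfur

This account rests on a few compounds, and the source may have more. Where it says the series, first, only, none or still open, it means among the compounds named here.

In a functional assay on DU-145 cells (Homo sapiens) for inhibition, read by trypan blue exclusion, with a stated time of 96 h (on this read-out lower numbers stand for stronger inhibition of growth and higher numbers for weaker inhibition of growth), compound 2 `O=C(/C(=C\c1ccc(Br)cc1)S(=O)(=O)c1ccc(Br)cc1)c1ccc(Br)cc1` gives 10000 nM and stands level with compound 3 `O=C(/C(=C\c1ccc(Cl)cc1Cl)S(=O)(=O)c1ccc(Br)cc1)c1ccc(Br)cc1` at 10000 nM as the joint lowest of three numbers, while compound 1 `O=C(/C(=C\c1ccc(Cl)cc1)S(=O)(=O)c1ccc(Br)cc1)c1ccc(Br)cc1` gives 50000 nM in this assay as the highest. Compound 4 `O=C(/C(=C\c1ccc(Br)cc1)S(=O)(=O)c1ccccc1Br)c1ccc(Br)cc1` has the same atoms as compound 2 joined differently, with 2-bromophenyl in place of 4-bromophenyl on a sulfonyl sulfur is the counted change. The measured steps of a 5.0-fold lower number from compound 1 to compound 2 (0.70 log units; beyond the scatter) and a 5.0-fold lower number from compound 1 to compound 3 (0.70 log units; beyond the scatter) were modest and no change at the digits printed from compound 2 to compound 3 (within the scatter) stayed within the scatter, yet all three changed the group on the double-bonded chain carbon. Among the measured compounds shown here, no measured step changes the group on the sulfonyl sulfur, so no direction can be read from them and nothing beyond the scatter is expected. The expected step is a 1.2-fold higher number from compound 2 to compound 4 (0.08 log units; within the scatter) on this evidence. Compound 4 is estimated at 12000 nM in this assay with a range from 3000 nM to 40000 nM as its likely span.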

Compound 4, concentration for 50% growth inhibition: 1000 nM
For compound 4 the middle estimate is 12-fold (1.08 log units) above the measured one; the whole stated range lies above it.
By their numbers in this assay, from the lowest: compound 4; then compounds 2 and 3 (each within the scatter of the next); then compound 1.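

Moving the bromine within the ring on the sulfonyl sulfur adds and removes no atoms, yet it gives a 10-fold lower number from compound 2 to compound 4 (1.00 log units; beyond the scatter) in this assay. This position therefore responds to the placement of a group and not only to its make-up, which compounds 1, 2 and 3, all with 4-bromophenyl here, could not show. Nothing available here explains this step.

Still open, as far as these compounds go, is whether a methoxy group or an amine in place of the bromine would keep the stronger inhibition. From the compounds shown here alone, whether 2-bromophenyl has the same effect with the groups of compound 1 or compound 3 also remains unknown.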